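Swapping a flexible ether chain for a flat ring

The compounds below may be only part of what the source reports. "The series", "measured", "known", "first", "only" and "open" are said of these compounds alone.

Compound 1 `CN1CCN(c2nc3ccccc3n2CCOc2ccccc2)CC1` gives 6.9 nM in a functional assay on ileum for inhibition of histamine H1 receptor (Cavia porcellus); a higher number here means a weaker inhibitor, a lower number a stronger inhibitor.
Compound 2 `CCCOCCn1c(N2CCN(C)CC2)nc2ccccc21` gives 20 nM in this assay.
Compound 3 `CCCCCCCCCCn1c(N2CCN(C)CC2)nc2ccccc21` gives 4200 nM in this assay.

Compound 2 sits second of the three: compound 1 gives a lower number, compound 3 a far higher one. Compound 4 `CN1CCN(c2nc3ccccc3n2-c2ccccc2)CC1` differs from compound 2 by phenyl in place of 2-propoxyethyl on an aromatic nitrogen. The measured steps bear on it only indirectly. Trading phenyl for propyl on the oxygen cost little, a 2.9-fold higher number from compound 1 to compound 2 (0.46 log units; beyond the scatter), whereas removing the oxygen altogether in favour of a plain chain cost much, a 210-fold higher number from compound 2 to compound 3 (2.32 log units; beyond the scatter) and a 610-fold higher number from compound 1 to compound 3 (2.78 log units; beyond the scatter). Compound 4 also loses the oxygen, so a clear weakening is expected, a 15-fold higher number from compound 2 to compound 4 (1.18 log units; beyond the scatter), though smaller than with the long chain. Compound 4 is estimated at 300 nM, between 40 nM and 3000 nM.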

Compound 4, half-maximal inhibitory concentration: 760 nM
Estimate against measurement, compound 4: 2.5-fold (0.40 log units) below; the measured number falls inside the stated range.
By their numbers in this assay, from the lowest: compound 1; then compound 2; then compound 4; then compound 3.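

Phenyl and 2-propoxyethyl have the same count of heavy atoms, yet the swap on this aromatic nitrogen gives a 38-fold higher number from compound 2 to compound 4 (1.58 log units; beyond the scatter), so matching that count does not preserve the strength of inhibition. The phenyl ring alone does not suffice either: compound 1, which holds it at the end of an ether chain, gives 6.9 nM, while compound 4, which holds it directly on the nitrogen, gives 760 nM. No measurement shown here explains this loss. Going by these compounds, it remains open whether a benzyl or 2-phenylethyl group on this nitrogen would bring the number back down.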